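Selenium-bearing fused cores against a colon cancer cell line

The source may report more compounds than this note shows. Statements on the series, on what has been measured and on what is new or still open speak of the compounds shown alone.

Measured so far:
- compound 1 `C[Se]c1nc([Se]C)c2cccnc2n1` — "not determined" (no result reported) in a functional assay on HT-29 cells (Homo sapiens) for cytotoxicity, read by MTT assay, with a stated time of 72 h; a lower number here means that less compound is tolerated, a higher number that more compound is tolerated
- compound 2 `[SeH]c1nc(NCc2ccccc2)c2cccnc2n1` — > 100000 nM in this assay, a limit of the assay
- compound 3 `CSc1nc(NCc2ccccc2)c2ccccc2n1` — > 100000 nM in this assay, a limit of the assay

Compound 1 has no number of its own in this assay; the two values it can be set against are both limits, as shown by the limit of > 100000 nM in this assay, at which 2 of the 3 values shown sit. Compound 4 `C[Se]c1nc(N)c2cccnc2n1` keeps the core of compound 1 but differs by one nitrogen atom in place of a group of 2 heavy atoms (1 carbon, 1 selenium; no ring), on an aromatic carbon, in words: one nitrogen atom in place of a group of 2 heavy atoms (1 carbon, 1 selenium; no ring), on an aromatic carbon, the entering group being an amino. Among the compounds with values here, no measured step bears on this change, so nothing beyond the scatter is expected in either direction in this assay. Compound 4 is therefore estimated at 100000 nM, in a range from 30000 nM to 300000 nM.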

Compound 4, concentration lethal to 50% of the cells: > 100000 nM
Compound 4 gave a limit, no number (the forecaster's own chance of this, stated with the estimate: 70%); the middle value sits exactly at the limit.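

Within the data shown here, compound 1 has no number and compound 4 gives only a limit, so no step between them can be read: the limit of > 100000 nM in this assay, at which 3 of the 4 values shown sit. Left open is what actual lethal concentration any of these compounds has in this assay.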